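Swapping a bromine for a methyl on the ester-bearing ring

The source may report more compounds than this note shows. Statements on the series, on what has been measured and on what is new or still open speak of the compounds shown alone.

Measured compounds:
Compound 1: `COC(=O)c1ccc(Cl)cc1OC(=O)COc1cc(O)c2c(=O)cc(-c3ccccc3)oc2c1`, 12400 nM
Compound 2: `COC(=O)c1cc(O)ccc1OC(=O)COc1cc(O)c2c(=O)cc(-c3ccccc3)oc2c1`, 29500 nM
Compound 3: `COC(=O)c1c(Br)cccc1OC(=O)COc1cc(O)c2c(=O)cc(-c3ccccc3)oc2c1`, 41700 nM

All three compounds share one core and differ only in the ring that sits on an oxygen next to a carbonyl group. In a functional assay on cells (T-cell, Mus musculus, strain BALB/c) for inhibition, read by MTT assay, with a stated time of 72 h (a higher number here means a weaker inhibitor, a lower number a stronger inhibitor), compound 3 gives 41700 nM, the highest of the three numbers. Its nearest neighbour is compound 2, which gives 29500 nM; the gap a 1.4-fold higher number from compound 2 to compound 3 (0.15 log units; within the scatter) lies within the scatter. The widest gap is to compound 1, which gives 12400 nM, with the step of a 3.4-fold higher number from compound 1 to compound 3 (0.53 log units; beyond the scatter) beyond the scatter. Compound 1 also stands apart from compound 2 by a 2.4-fold higher number from compound 1 to compound 2 (0.38 log units; beyond the scatter).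

Compound 4 has the structure `COC(=O)c1cc(C)ccc1OC(=O)COc1cc(O)c2c(=O)cc(-c3ccccc3)oc2c1`. The change from compound 3 is a group of 11 heavy atoms (9 carbon, 2 oxygen; one six-membered aromatic ring of carbon only) in place of a group of 11 heavy atoms (8 carbon, 2 oxygen, 1 bromine; one six-membered aromatic ring of carbon only), on an oxygen next to a carbonyl group. For the measured compounds named here, no measured step exchanges a bromine for a methyl, so the closest guidance is that swapping one ring substituent for another has moved the number by at most a modest amount, and in one case not beyond the scatter. A methyl-bearing ring is therefore expected to land in the same neighbourhood, and the expected step of a 1.7-fold lower number from compound 3 to compound 4 (0.22 log units; within the scatter) is likely small, with no confident direction. Compound 4 is estimated at 25000 nM, within a range from 9000 nM to 70000 nM.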

Compound 4, half-maximal inhibitory concentration: 25700 nM
Beside the measured number, compound 4's estimate is 1.0-fold (0.01 log units) below it, within the range that was stated.
By their numbers in this assay, from the lowest: compound 1; then compounds 4, 2 and 3 (each within the scatter of the next).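

In this assay the new result supplies a direct exchange of hydroxy for methyl on an aromatic carbon, and with a 1.1-fold lower number from compound 2 to compound 4 (0.06 log units; within the scatter) the two groups cannot be told apart on this ring. The bromine-bearing ring cannot be told apart from the methyl-bearing ring either, since a 1.6-fold lower number from compound 3 to compound 4 (0.21 log units; within the scatter) lies within the scatter, so three of the four rings now sit together, each within the scatter of the next. Only the chlorine-bearing ring of compound 1 stands apart, and with a 2.1-fold higher number from compound 1 to compound 4 (0.32 log units; beyond the scatter) added to its earlier steps, its number is now lower than each of the other three by more than the scatter, although the gap to compound 4 is only modest.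

Nothing in the data shown offers an explanation for this pattern. As far as these compounds go, whether a ring carrying an amine or a carboxylic acid in place of the methyl would leave the number in this same neighbourhood or move it well away stays open.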